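Bromoacrylamide chalcones: effect of removing the acylating group

The source may report more compounds than this note shows. Statements on the series, on what has been measured and on what is new or still open speak of the compounds shown alone.

Compound 1 `C=C(Br)C(=O)Nc1ccc(/C=C/C(=O)c2ccccc2)cc1` carries a (1-bromoethenyl)carbonyl on the aromatic amine nitrogen; in a functional assay on MOLT-4 cells (Homo sapiens) for antiproliferative activity, with a stated time of 48 h (a higher number here means a weaker inhibitor, a lower number a stronger inhibitor), compound 1 gives 3100 nM. Compound 2 `C=C(Br)C(=O)Nc1ccc(/C=C/C(=O)c2cc(OC)c(OC)c(OC)c2)cc1` keeps that group but differs from compound 1 in the other aryl part of the core; the difference between the two cores is not broken down here. In this assay compound 2 gives 850 nM, the lowest number of the three measured compounds, and its steps to compound 1 and to compound 3 both lie beyond the scatter. Compound 3 `Nc1ccc(/C=C/C(=O)c2ccccc2)cc1` is the free amine of compound 1; the change is hydrogen in place of (1-bromoethenyl)carbonyl on a nitrogen on an aromatic ring. In this assay compound 3 gives 10000 nM. The removal weakens inhibition: a 3.2-fold higher number from compound 1 to compound 3 (0.51 log units; beyond the scatter).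

Compound 4 `COc1cc(C(=O)/C=C/c2ccc(N)cc2)cc(OC)c1OC` is the free amine of compound 2, the change being (hydrogen in place of (1-bromoethenyl)carbonyl on a nitrogen on an aromatic ring). The place of the change reads the same in both pairs, so this is the same change, seen here for the second time; its transfer to compound 2 rests on a single measured step and on the assumption that the trimethoxy-bearing core behaves like the core of compound 1. From compound 2 to compound 4 the step is expected to be a 3.2-fold higher number from compound 2 to compound 4 (0.50 log units; beyond the scatter), because the same change gave a 3.2-fold higher number from compound 1 to compound 3 (0.51 log units; beyond the scatter). Compound 4 is therefore expected to give about 2700 nM in this assay, with the likely span estimated from 1200 nM to 6500 nM.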

Compound 4, half-maximal inhibitory concentration: 1500 nM
The estimate for compound 4 lay 1.8-fold (0.26 log units) above the measured number; low and high end bracket the measured number.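

On the core of compound 2, putting hydrogen in place of (1-bromoethenyl)carbonyl on the aromatic nitrogen gives, in this assay, a 1.8-fold higher number from compound 2 to compound 4 (0.25 log units; within the scatter), so on this core the step itself cannot be told from repeat-measurement noise, whereas on the core of compound 1 it can. Set side by side, the two steps cannot be told apart: the same change on two cores in this assay, a 3.2-fold higher number (0.51 log units; beyond the scatter) from compound 1 to compound 3 and a 1.8-fold higher number (0.25 log units; within the scatter) from compound 2 to compound 4, 1.8-fold (0.26 log units) apart, within the scatter of two such steps. The data therefore fit a change that carries between these two cores at a similar size, but they rest on one pair per core and show neither that the step is truly the same on both nor that the (1-bromoethenyl)carbonyl group contributes measurably on the core of compound 2, and they say nothing about any further core.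

As far as these compounds go, it remains open whether the bromine or the whole acyl group accounts for the step on the core of compound 1, a question that an unbrominated acryloyl group or a simple acetyl group on the same nitrogen would address. From the compounds shown here alone, it also remains open whether the step holds on a third core, for instance one carrying a single methoxy group or a chlorine on the other aryl part.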